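The source may report more compounds than this note shows. Statements on the series, on what has been measured and on what is new or still open speak of the compounds shown alone.

In a functional assay on GBM2 cells (Homo sapiens) for antiproliferative activity, read by WST assay, with a stated time of 72 h (on this read-out higher numbers stand for weaker inhibition and lower numbers for stronger inhibition), compound 1 (`O=C(Nc1ccc(C(F)(F)F)cc1)Nc1cc2ncncc2cc1OCc1cccc(F)c1`) gives 3200 nM and compound 2 (`O=C(Nc1ccc(Cl)c(Cl)c1)Nc1cc2ncncc2cc1OCc1ccccc1F`) gives 6000 nM so these two values lie within the scatter of each other. Compound 3 (`O=C(Nc1ccc(Cl)c(Cl)c1)Nc1cc2ncncc2cc1OCc1cccc(F)c1`) has 3-fluorophenyl in place of 2-fluorophenyl on a saturated chain carbon bound to an oxygen on an aromatic ring. Within the data shown here, no measured step isolates this change, and no shift beyond the scatter is expected in this assay in either direction. The estimated step of a 1.3-fold lower number from compound 2 to compound 3 (0.12 log units; within the scatter) is expected to stay within that scatter. For compound 3 the estimated value is 4500 nM with an expected range of 1800 nM to 11000 nM in this read-out.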

Compound 3, half-maximal inhibitory concentration: 1500 nM
For compound 3 the middle estimate is 3.0-fold (0.48 log units) above the measured one, and the stated range ends above it.
By their numbers in this assay, from the lowest: compound 3; then compounds 1 and 2 (each within the scatter of the next).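

In this assay, 3-fluorophenyl in place of 2-fluorophenyl on a saturated chain carbon bound to an oxygen on an aromatic ring gives a 4.0-fold lower number from compound 2 to compound 3 (0.60 log units; beyond the scatter) with the same atoms, so the place of the fluorine on this ring counts here. With the 3-fluorobenzyl group held, 3,4-dichlorophenyl in place of 4-(trifluoromethyl)phenyl on an amide-type nitrogen gives a 2.1-fold lower number from compound 1 to compound 3 (0.33 log units; beyond the scatter) and shows that this second site also counts. No measurement at hand explains either step.

As far as these compounds go, it stays open whether an unsubstituted benzyl or a pyridylmethyl group would fit this position, and whether the fluorine step holds alongside 4-(trifluoromethyl)phenyl.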